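The source may hold more compounds than are shown below. What is called first, only, known or untested is meant among the compounds shown, and "the series" means these compounds.

In a functional assay on MCF7 cells (Homo sapiens) for cytotoxicity, read by MTT assay, with a stated time of 72 h (on this read-out lower numbers stand for stronger inhibition and higher numbers for weaker inhibition), compound 3 `Cc1cc(=O)n(-c2cccc(F)c2)nc1C(=O)Nc1ccc(Oc2ncnc3[nH]ccc23)c(F)c1` gives 32000 nM, the highest number of the three measured. Compound 2 `Cc1cc(=O)n(-c2ccc(F)cc2)nc1C(=O)Nc1ccc(Oc2ncnc3[nH]ccc23)c(F)c1` gives 24500 nM. Among the measured compounds shown here, the one single-point step known, a 1.3-fold higher number from compound 2 to compound 3 (0.12 log units; within the scatter), is an aryl swap on the same nitrogen and lies within the scatter. Compound 1 `Cc1ccc(-n2nc(C(=O)Nc3ccc(Oc4ncnc5[nH]ccc45)cc3)c(C)cc2=O)cc1` gives 3620 nM, but differs from compound 3 in two places, so its lower number cannot be assigned to either change alone. Compound 4 `Cc1ccc(-n2nc(C(=O)Nc3ccc(Oc4ncnc5[nH]ccc45)c(F)c3)c(C)cc2=O)cc1` arises from compound 3 by 4-methylphenyl in place of 3-fluorophenyl on an aromatic nitrogen. The measured aryl swap was flat, while compound 1 shows 4-methylphenyl in a lower-number context; a downward step of uncertain size is therefore expected, a 3.6-fold lower number from compound 3 to compound 4 (0.55 log units; beyond the scatter). Compound 4 is estimated at 9000 nM, with a range of 2500 nM to 32000 nM.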

Compound 4, half-maximal inhibitory concentration: 18900 nM
Beside the measured number, compound 4's estimate is 2.1-fold (0.32 log units) below it; measured number inside the range.
By their numbers in this assay, from the lowest: compound 1; then compounds 4, 2 and 3 (each within the scatter of the next).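

In this assay, with fluoro on the shared core, the swap to 4-methylphenyl on the aromatic nitrogen stays within the scatter (a 1.7-fold lower number from compound 3 to compound 4 (0.23 log units; within the scatter)), as does methyl in place of fluoro on the aryl ring (a 1.3-fold lower number from compound 2 to compound 4 (0.11 log units; within the scatter)). Among the compounds shown here, the only step here beyond the scatter is fluoro in place of hydrogen on an aromatic carbon of the core (a 5.2-fold higher number from compound 1 to compound 4 (0.72 log units; beyond the scatter)), so the lower number of compound 1 goes with that hydrogen, not with 4-methylphenyl. Nothing on hand accounts for this step. Open, on these data alone, is whether an amine or a carboxylic acid on the aryl ring would shift the number, and whether the fluoro step holds with other aryl groups.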